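A few compounds are considered here, and "the series" means these few. Any claim that something is new, unique, unknown or untested is made for them only; others in the source may bear on it.

Measured so far in an assay on isolated protein for binding affinity to Adrenergic receptor alpha-1 (Homo sapiens); on this read-out higher numbers stand for weaker inhibition and lower numbers for stronger inhibition:
compound 1, `COc1ccccc1N1CCN(CCn2c(=O)[nH]c3[nH]c(-c4ccccc4C)cc3c2=O)CC1`; compound 1 gives 1.19 nM
compound 2, `COc1ccccc1-c1cc2c(=O)n(CCN3CCN(c4ccccc4OC)CC3)c(=O)[nH]c2[nH]1`; compound 2 gives 1.63 nM

Compound 2 has the higher of the two numbers in this assay, but the gap to compound 1 is small: the step of a 1.4-fold higher number from compound 1 to compound 2 (0.14 log units; within the scatter) lies within the scatter. Compound 3, `COc1ccccc1N1CCN(CCn2c(=O)[nH]c3[nH]c(-c4ccc(C)cc4)cc3c2=O)CC1`, is not yet measured. Relative to compound 2 the change is 4-methylphenyl in place of 2-methoxyphenyl on an aromatic carbon. Going by the values given here, only one measured step bears on this: the exchange of the substituent on that pendant ring from compound 1 to compound 2, which gave a 1.4-fold higher number from compound 1 to compound 2 (0.14 log units; within the scatter) and so left the number essentially unchanged. Among the compounds with values here, no measured pair carries a 4-methylphenyl on the core, so the effect of that arrangement itself is unknown. Within the data shown here, on the one step available, variation of that ring appears tolerated, and no step beyond the scatter is expected for compound 3 in this assay; the expected step is a 1.0-fold lower number from compound 2 to compound 3 (0.01 log units; within the scatter). Compound 3 is estimated at 1.6 nM, with a range from 0.5 nM to 5 nM.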

Compound 3, inhibition constant: 4.97 nM
Compound 3: middle estimate off by 3.1-fold (0.49 log units), on the low side, within the range that was stated.
By their numbers in this assay, from the lowest: compounds 1 and 2 (each within the scatter of the next); then compound 3.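

In this assay, this aromatic carbon next to the ring nitrogen proves less tolerant than the earlier step suggested: 4-methylphenyl in place of 2-methylphenyl gives a modest loss (a 4.2-fold higher number from compound 1 to compound 3 (0.62 log units; beyond the scatter)), and 4-methylphenyl in place of 2-methoxyphenyl gives a similar one (a 3.0-fold higher number from compound 2 to compound 3 (0.48 log units; beyond the scatter)). The exchange of methyl for methoxy (a 1.4-fold higher number from compound 1 to compound 2 (0.14 log units; within the scatter)) therefore did not show the whole picture: among these three compounds, only the 4-methylphenyl group separates from the others, and the change remains modest. The data shown offer no explanation for this separation.

Open, on these data alone, is whether 4-methoxyphenyl would read like 4-methylphenyl, which would separate the place of the substituent from its identity, and where unsubstituted phenyl would fall. As far as these compounds go, all three compounds also share the same chain on the core, so the effect of a longer chain remains open.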